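Swapping bromo for methoxy on a butyrolactone aryl ring

This account rests on a few compounds, and the source may have more. Where it says the series, first, only, none or still open, it means among the compounds named here.

Compound 1 `C=C1C(=O)O[C@H](C)[C@@H]1c1ccc([N+](=O)[O-])cc1`: 21700 nM
Compound 2 `C=C1C(=O)O[C@H](C)[C@@H]1c1ccc(Br)cc1`: 4280 nM
Compound 3 `C=C1C(=O)O[C@@H](C)[C@@H]1c1ccc(Br)cc1`: 6660 nM

In a functional assay on HL-60 cells (Homo sapiens) for cytotoxicity, read by MTT assay, with a stated time of 48 h (on this read-out lower numbers stand for stronger inhibition and higher numbers for weaker inhibition), compound 2 gives the lowest of the three numbers. Compound 3 sits close to it, with a 1.6-fold higher number from compound 2 to compound 3 (0.19 log units; within the scatter), a gap that rests only on (the fact that compounds 2 and 3 differ only in the configuration as drawn). Among the compounds with values here, compound 1 stands furthest away, and the step of a 5.1-fold lower number from compound 1 to compound 2 (0.71 log units; beyond the scatter) is the one clear change among the measured compounds.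

Compound 4 `C=C1C(=O)O[C@H](C)[C@@H]1c1ccc(OC)cc1` has not yet been measured. It differs from compound 2 by methoxy in place of bromo on an aromatic carbon. Within the data shown here, no measured compound carries a methoxy group, so the only step that bears on this change is the one from nitro to bromo, a 5.1-fold lower number from compound 1 to compound 2 (0.71 log units; beyond the scatter), which shows that the group on this aromatic carbon can move the number by a modest amount. Methoxy is neither of those groups, so no direction can be read off with confidence. The expectation is therefore a modest rise in the number, a 1.9-fold higher number from compound 2 to compound 4 (0.27 log units; within the scatter), within a wide range. The estimate for compound 4 in this assay is 8000 nM, between 3000 nM and 30000 nM.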

Compound 4, half-maximal inhibitory concentration: 4820 nM
Beside the measured number, compound 4's estimate is 1.7-fold (0.22 log units) above it, and the stated range covers the measured number.
By their numbers in this assay, from the lowest: compounds 2, 4 and 3 (each within the scatter of the next); then compound 1.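

With methoxy in place of bromo, this assay shows a 1.1-fold higher number from compound 2 to compound 4 (0.05 log units; within the scatter) and so does not separate these two groups on this aromatic carbon. This holds even though the swap goes from 1 heavy atom to 2 heavy atoms and from 0 hydrogen-bond acceptors to 1 hydrogen-bond acceptor. Nitro now stands apart from two different groups rather than one: a 4.5-fold lower number from compound 1 to compound 4 (0.65 log units; beyond the scatter) joins a 5.1-fold lower number from compound 1 to compound 2 (0.71 log units; beyond the scatter) as a step beyond the scatter, so the earlier gap was not special to bromo.

As far as these compounds go, whether an amine or a carboxylic acid on this aromatic carbon would give a number close to those of compound 2 and compound 4, or one nearer to that of compound 1, remains open. Nothing available here explains why nitro stands apart from bromo and methoxy.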